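Swapping the Aryl Group on a Shared Core

The source may hold more compounds than are shown below. What is called first, only, known or untested is meant among the compounds shown, and "the series" means these compounds.

Compound 2 `C=C/C=C\[C@H](C)[C@H](OC(N)=O)[C@@H](C)[C@H](O)[C@@H](C)C/C(C)=C\[C@H](C)[C@@H](O)[C@@H](C)/C=C\CCc1cc(F)cc(F)c1` gives 600 nM in a functional assay on MCF7 cells (Homo sapiens) for cytotoxicity; a higher number here means a weaker inhibitor, a lower number a stronger inhibitor. Among the three measured compounds its number is the second highest: compound 1 `C=C/C=C\[C@H](C)[C@H](OC(N)=O)[C@@H](C)[C@H](O)[C@@H](C)C/C(C)=C\[C@H](C)[C@@H](O)[C@@H](C)/C=C\CCc1cccc(O)c1C` gives 490 nM and compound 3 `C=C/C=C\[C@H](C)[C@H](OC(N)=O)[C@@H](C)[C@H](O)[C@@H](C)C/C(C)=C\[C@H](C)[C@@H](O)[C@@H](C)/C=C\CCc1ccsc1` gives 850 nM. The steps of a 1.2-fold higher number from compound 1 to compound 2 (0.09 log units; within the scatter) and a 1.4-fold higher number from compound 2 to compound 3 (0.15 log units; within the scatter), as well as a 1.7-fold higher number from compound 1 to compound 3 (0.24 log units; within the scatter), all lie within the scatter, so the aryl exchanges seen so far leave this assay essentially unchanged. Compound 4 `C=C/C=C\[C@H](C)[C@H](OC(N)=O)[C@@H](C)[C@H](O)[C@@H](C)C/C(C)=C\[C@H](C)[C@@H](O)[C@@H](C)/C=C\CCc1cc(O)cc(O)c1` carries the change (3,5-dihydroxyphenyl in place of 3,5-difluorophenyl on a saturated chain carbon, two bonds along the chain from a double-bonded chain carbon). Within the data shown here, no measured step puts a 3,5-dihydroxyphenyl in place of anything, and none of the three bearing steps moved the number beyond the scatter, so no step beyond the scatter is expected here either. Compound 4 is therefore estimated at 550 nM, between 250 nM and 1300 nM, which means an expected step of a 1.1-fold lower number from compound 2 to compound 4 (0.04 log units; within the scatter).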

Compound 4, half-maximal inhibitory concentration: 160 nM
Compound 4: middle estimate off by 3.4-fold (0.54 log units), on the high side; the measured number lies below the stated range.
By their numbers in this assay, from the lowest: compound 4; then compounds 1, 2 and 3 (each within the scatter of the next).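

In this assay the aryl group at this position does matter: the step of a 3.8-fold lower number from compound 2 to compound 4 (0.57 log units; beyond the scatter) for 3,5-dihydroxyphenyl in place of 3,5-difluorophenyl lies beyond the scatter, unlike every earlier exchange. The steps of a 5.3-fold lower number from compound 3 to compound 4 (0.73 log units; beyond the scatter) from thiophen-3-yl and a 3.1-fold lower number from compound 1 to compound 4 (0.49 log units; beyond the scatter) from 3-hydroxy-2-methylphenyl agree, so compound 4 stands apart from all three earlier compounds. Nothing shown explains this difference. As far as these compounds go, whether the lower number would survive with methoxy groups or amines in place of the hydroxyl groups remains open.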